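The compounds below may be only part of what the source reports. "The series", "measured", "known", "first", "only" and "open" are said of these compounds alone.

Measured compounds in a functional assay on cells for agonist activity at Free fatty acid receptor 1 (Homo sapiens), read by calcium flux; a lower number here means that less compound is needed, a higher number that more compound is needed for the effect:
compound 1, `Cc1cccc(C)c1-c1cccc(COc2ccc(CC3SC(=O)NC3=O)s2)c1`, 82 nM
compound 2, `CC#CC(CC(=O)O)c1ccc(OCc2cccc(-c3c(C)cccc3C)c2)s1`, 210 nM
compound 3, `COC(CC(=O)O)c1ccc(OCc2cccc(-c3c(C)cccc3C)c2)s1`, 210 nM

Compound 2 stands level with compound 3 at the digits shown, the two together giving the highest numbers of the three; its nearest neighbour is compound 3, no change at the digits printed from compound 2 to compound 3 (within the scatter), and its furthest is compound 1, a 2.6-fold higher number from compound 1 to compound 2 (0.41 log units; beyond the scatter). Compound 4, `CC#CC(CC(=O)O)c1ccc(OCc2cccc(-c3c(C)cc(OCCCS(C)(=O)=O)cc3C)c2)s1`, is not yet measured. It differs from compound 2 in one place: 3-(methylsulfonyl)propoxy in place of hydrogen on an aromatic carbon.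

For the measured compounds named here, none of the measured steps touches this part of the shared core. The steps of a 2.6-fold higher number from compound 1 to compound 2 (0.41 log units; beyond the scatter) and a 2.6-fold higher number from compound 1 to compound 3 (0.41 log units; beyond the scatter) both swap the acid-bearing end, and no change at the digits printed from compound 2 to compound 3 (within the scatter) alters the chain carbon next to that end; all leave the dimethylphenyl ring untouched. Going by the values given here, there is thus no direct precedent for the change to compound 4, and the expectation is a step of a 1.1-fold lower number from compound 2 to compound 4 (0.02 log units; within the scatter), that is, no change beyond the scatter, with a wide band around it. Compound 4 is estimated at 200 nM, within 60 nM to 700 nM.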

Compound 4, half-maximal effective concentration: 240 nM
Compound 4: middle estimate off by 1.2-fold (0.08 log units), on the low side; the range from low to high includes it.
By their numbers in this assay, from the lowest: compound 1; then compounds 2, 3 and 4 (each within the scatter of the next).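

In this assay, putting 3-(methylsulfonyl)propoxy in place of hydrogen on the aromatic carbon para to a large group and meta to two methyl groups gives a 1.1-fold higher number from compound 2 to compound 4 (0.06 log units; within the scatter) and so no difference that can be told from the scatter. For the compounds shown here, this is the first look at this position, as the earlier steps changed only the acid-bearing end, and it shows that a chain of this size, with no ring and no net charge, can stand here while the number stays level with that of compound 2. Nothing shown bears on why this substitution leaves the number level.

The compounds shown leave open whether an amine or a carboxylic acid in place of the methylsulfonyl end, or a longer chain, would also keep the number level. They also leave open whether 3-(methylsulfonyl)propoxy at this position would give the same result on compound 1 or compound 3.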